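The source may hold more compounds than are shown below. What is called first, only, known or untested is meant among the compounds shown, and "the series" means these compounds.

In an assay on LtK cells with ATP-sensitive inward rectifier potassium channel 11 (Homo sapiens) as the target (on this read-out lower numbers stand for an effect already at smaller amounts and higher numbers for an effect only at larger amounts of compound), compound 1 `O=C(NCCCCCCCl)Nc1c(C(O)(C(F)(F)F)C(F)(F)F)ccc2ccccc12` gives 4840 nM and compound 2 `Cc1ccccc1C(=O)Nc1c(C(O)(C(F)(F)F)C(F)(F)F)ccc2ccccc12` gives 5550 nM; the pair shows a 1.1-fold higher number from compound 1 to compound 2 (0.06 log units; within the scatter). Compound 3 `O=C(Nc1c(C(O)(C(F)(F)F)C(F)(F)F)ccc2ccccc12)c1cccc(Cl)c1` gives 98 nM, the lowest of the three numbers, reached through a 49-fold lower number from compound 1 to compound 3 (1.69 log units; beyond the scatter) and a 57-fold lower number from compound 2 to compound 3 (1.75 log units; beyond the scatter). Compound 4 `COc1cccc(C(=O)Nc2c(C(O)(C(F)(F)F)C(F)(F)F)ccc3ccccc23)c1` keeps the shared core of compound 3 and differs only in methoxy in place of chloro on an aromatic carbon. For the measured compounds named here, no measured step swaps one group for another on this ring; the measured steps only show that the chlorophenyl carbonyl of compound 3 lies far below the other two. Compound 4 is therefore expected to land somewhat higher, with a 3.1-fold higher number from compound 3 to compound 4 (0.49 log units; beyond the scatter) as the estimated step. For compound 4 the expected value in this assay is 300 nM, estimated between 80 nM and 1500 nM.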

Compound 4, half-maximal effective concentration: 185 nM
Beside the measured number, compound 4's estimate is 1.6-fold (0.21 log units) above it; the range from low to high includes it.
By their numbers in this assay, from the lowest: compounds 3 and 4 (each within the scatter of the next); then compounds 1 and 2 (each within the scatter of the next).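

Chloro and methoxy on this aromatic carbon cannot be told apart in this assay with a 1.9-fold higher number from compound 3 to compound 4 (0.28 log units; within the scatter) even though methoxy brings a hydrogen-bond acceptor that chloro lacks. Low numbers are thus not limited to the chloro compound, as the methoxy compound also sits far under the other two with a 30-fold lower number from compound 2 to compound 4 (1.48 log units; beyond the scatter) and a 26-fold lower number from compound 1 to compound 4 (1.42 log units; beyond the scatter) in these two comparisons. No evidence at hand offers an explanation for this. On these data alone, whether an amine or a carboxylic acid on the same aromatic carbon would keep the number this low remains open.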